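Trading the acetyl of compound 1 for a methyl

The source may hold more compounds than are shown below. What is called first, only, known or untested is meant among the compounds shown, and "the series" means these compounds.

Compound 1 `CC(=O)Nc1c(C)nc2c(OCc3ccccc3)cccn12` stands highest of the two numbers seen in a functional assay on the whole organism with Rattus norvegicus as the target, at a dose of 40 mg/kg by the intraperitoneal route (on this read-out higher numbers stand for more inhibition at the one dose given (going by the name of the read-out) and lower numbers for less inhibition), giving 93%; compound 2 `Cc1nc2c(OCc3ccccc3)cccn2c1NC(=O)OCc1ccccc1` gives 8%. The change to compound 3 `CNc1c(C)nc2c(OCc3ccccc3)cccn12` is methyl in place of acetyl on a nitrogen on an aromatic ring. Among the measured compounds shown here, only one measured step touches the same nitrogen, and it was large: a number 85 percentage points lower from compound 1 to compound 2 (beyond the scatter), where benzyloxy replaced methyl on the carbonyl carbon. That step does not test removal of the carbonyl itself, so the direction is uncertain, but a large downward step is plausible. For compound 3 the expected value in this assay is 50%, ranging from 10% to 90%, an estimated step of a number 43 percentage points lower from compound 1 to compound 3 (beyond the scatter).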

Compound 3, a percentage reported as inhibition, in the whole organism at one dose (the size of the read-out at that dose, not a potency): 55%
Compound 3: middle estimate off by 5 percentage points, on the low side; the measured number falls inside the stated range.
By their numbers in this assay, from the lowest: compound 2; then compound 3; then compound 1.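

Swapping acetyl for methyl on this nitrogen gives a number 38 percentage points lower from compound 1 to compound 3 (beyond the scatter), so in this assay methylamino does not match acetamido, yet the number does not collapse. Compound 3 has no carbonyl at this place and gives 55%, whereas compound 2 keeps a carbonyl there and gives 8%, so the presence of a carbonyl alone does not set the number. Nothing measured here explains these differences.

Still open, on these data alone, is where an unsubstituted amine on this nitrogen would fall, and whether a longer acyl chain, such as propionyl, would match the acetyl of compound 1.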